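A few compounds are considered here, and "the series" means these few. Any claim that something is new, unique, unknown or untested is made for them only; others in the source may bear on it.

Compound 1 `O=C(Nc1ccccc1)Nc1nc(NC2CC2)cc(Sc2c[nH]c3ccccc23)n1`: 17500 nM
Compound 2 `Cc1ccc(C)c(NC(=O)Nc2nc(Sc3c[nH]c4ccccc34)cc(N3CCN(Cc4ccccc4)CC3)n2)c1`: 17300 nM

Both numbers come from a functional assay on PC-3 cells (Homo sapiens) for inhibition, with a stated time of 72 h; on this read-out higher numbers stand for weaker inhibition and lower numbers for stronger inhibition. Compound 1 gives 17500 nM there, and compound 2 gives 17300 nM, so the two sit within the usual scatter of each other and neither can be called the stronger inhibitor. Compound 3 `O=C(Nc1ccccc1)Nc1nc(Nc2ccc(Cl)cc2)cc(Sc2c[nH]c3ccccc23)n1` has not yet been measured. It differs from compound 1 in a single place: 4-chlorophenyl in place of cyclopropyl on a nitrogen on an aromatic ring. Going by the values given here, no measured pair shows what such a change does, so the expectation rests on compound 1 alone. The step of a 1.9-fold lower number from compound 1 to compound 3 (0.29 log units; within the scatter) is expected to be a modest gain at most. For compound 3 the estimate is 9000 nM, with a range from 2500 nM to 30000 nM.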

Compound 3, half-maximal inhibitory concentration: 32300 nM
The estimate for compound 3 lay 3.6-fold (0.55 log units) below the measured number; the whole stated range lies below it.
By their numbers in this assay, from the lowest: compounds 2, 1 and 3 (each within the scatter of the next).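

Putting 4-chlorophenyl in place of cyclopropyl on this nitrogen gives a 1.8-fold higher number from compound 1 to compound 3 (0.27 log units; within the scatter) in this assay. The nitrogen therefore carries an aromatic ring of 7 heavy atoms as well as a ring of 3, with no difference that can be told from the scatter. Nothing measured here bears on why the two groups read alike.

Open, from the compounds shown here alone, is whether any group on this nitrogen can move the number beyond the scatter. A plain phenyl without the chlorine, or a chain ending in an amine or a carboxylic acid, would be among the groups still to compare.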